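The source may report more compounds than this note shows. Statements on the series, on what has been measured and on what is new or still open speak of the compounds shown alone.

In a functional assay on HeLa S3 cells (Homo sapiens) for antiproliferative activity, read by XTT assay, with a stated time of 72 h (a higher number here means a weaker inhibitor, a lower number a stronger inhibitor), compound 1 (`COc1nc(N)nc2c1c(-c1ccoc1)cn2[C@@H]1O[C@H](CO)[C@@H](O)[C@H]1O`) gives > 20000 nM as a limit of the assay. Compound 2 (`COc1nc(N)nc2c1c(-c1ccsc1)cn2[C@@H]1O[C@H](CO)[C@@H](O)[C@H]1O`) gives > 20000 nM as a limit too, and it thus stands at the limit of > 20000 nM in this assay, at which 2 of the 2 values shown sit, with no number to place it. Compound 3 (`COc1nc(N)nc2c1c(-c1ccccc1)cn2[C@@H]1O[C@H](CO)[C@@H](O)[C@H]1O`) differs from compound 2 by phenyl in place of thiophen-3-yl on an aromatic carbon with phenyl in place of thiophen-3-yl on an aromatic carbon. Among the compounds with values here, the one measured step (a step that the two limits leave unreadable from compound 1 to compound 2) has no readable size and so offers no measure for this change. No step beyond the scatter is expected in this assay here, and the expected step (a step that the limit leaves unreadable from compound 2 to compound 3) is only an estimate. For compound 3 the estimate is 25000 nM with an expected range from 10000 nM to 50000 nM and most likely only a limit reported.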

Compound 3, half-maximal inhibitory concentration: > 20000 nM
Compound 3: no number, only a limit (the forecaster's own chance of this, stated with the estimate: 85%); the middle value lies beyond the limit too.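

No step can be read among compound 1, compound 2 and compound 3, since all three stop at the same limit in this assay: the limit of > 20000 nM in this assay, at which 3 of the 3 values shown sit. The compounds shown leave open how far any of the three groups on that aromatic carbon differ in antiproliferative activity.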